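Dichlorophenylsulfonyl for indolylmethyl on the ring amine

The compounds below may be only part of what the source reports. "The series", "measured", "known", "first", "only" and "open" are said of these compounds alone.

Measured compounds in an in vitro functional assay on RBL cells for antagonist activity at C-C chemokine receptor type 8 (Homo sapiens), read by FLIPR and calcium flux; a higher number here means a weaker inhibitor, a lower number a stronger inhibitor:
- compound 1, `O=C1OC(c2ccc3ccccc3n2)CN1C1CCN(Cc2cc3ccccc3[nH]2)CC1`, gives < 50200 nM, a limit of the assay.
- compound 2, `COc1ccc2nccc(C3CN(C4CCN(Cc5c[nH]c6ccccc56)CC4)C(=O)O3)c2c1`, gives < 50200 nM, a limit of the assay.
- compound 3, `COc1ccc2nccc(C3CN(C4CCN(Cc5ccccc5)CC4)C(=O)O3)c2c1`, gives 12600 nM.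

Compound 2 thus stands at a limit only, as does one other value shown (the limit of < 50200 nM in this assay, at which 2 of the 3 values shown sit). Among the compounds with values here, the single measured step, a step that the limit leaves unreadable from compound 2 to compound 3, cannot be sized for that reason. Compound 4, `COc1ccc2nccc(C3CN(C4CCN(S(=O)(=O)c5ccc(Cl)c(Cl)c5)CC4)C(=O)O3)c2c1`, differs from compound 2 by (3,4-dichlorophenyl)sulfonyl in place of (1H-indol-3-yl)methyl on an amine nitrogen in a ring. Within the data shown here, no measured step bears readably on this change, and the only number in the set belongs to compound 3. Compound 4 is therefore estimated, with little support, at 12000 nM, in a range from 2000 nM to 50200 nM. The step that the limit leaves unreadable from compound 2 to compound 4 is expected to be of undetermined direction.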

Compound 4, half-maximal inhibitory concentration: < 50200 nM
Compound 4 ended at the assay's limit; the forecaster's own chance of this, stated with the estimate: 40%; the middle value is on the limit's open side.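

The steps to compound 4 from compound 2 and from compound 3 cannot be read, since compound 4 stands at a limit: the limit of < 50200 nM in this assay, at which 3 of the 4 values shown sit.

On these data alone, how (3,4-dichlorophenyl)sulfonyl compares with (1H-indol-3-yl)methyl or benzyl on the ring amine nitrogen remains open.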